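Methyl for phenyl on an amide-type ring nitrogen

The compounds below may be only part of what the source reports. "The series", "measured", "known", "first", "only" and "open" are said of these compounds alone.

Measured in (a functional assay on the whole organism for inhibition, with Rattus norvegicus as the target; on this read-out lower numbers stand for an effect already at smaller amounts and higher numbers for an effect only at larger amounts of compound):
- compound 1 (`O=C1N(CCN2CCC(c3cn(-c4ccc(F)cc4)c4ccc(Cl)cc34)CC2)CCN1c1ccccc1`): (> 0.15 umol/kg), a limit
- compound 2 (`Fc1ccc(-n2cc(C3=CCNCC3)c3cc(Cl)ccc32)cc1`): (1.5 umol/kg)

Compound 1 has no exact number on this read-out, only a limit (the limit of > 0.15 umol/kg in this assay, at which 1 of the 2 values shown sits). Among the compounds with values here, compound 2 supplies the only exact number so far (1.5 umol/kg).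

Compound 3 (`CN1CCN(CCN2CCC(c3cn(-c4ccc(F)cc4)c4ccc(Cl)cc34)CC2)C1=O`) keeps the core of compound 1 and changes one group: methyl in place of phenyl on an amide-type nitrogen in a ring. The group 2-oxo-3-phenylimidazolidin-1-yl thus becomes 3-methyl-2-oxoimidazolidin-1-yl (methyl in place of phenyl on an amide-type nitrogen in a ring).

Within the data shown here, no measured pair covers this change, so there is no direct precedent for its size or direction in (this assay). The working expectation is therefore no shift beyond the usual scatter, with the limit of compound 1 as the only anchor. The expected change is small (a step that the limit leaves unreadable from compound 1 to compound 3). The estimated value for compound 3 is (0.3 umol/kg), with an expected range from (0.07 umol/kg) to (1.3 umol/kg).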

Compound 3, dose for half-maximal effect: 0.021 umol/kg
The estimate for compound 3 lay 14-fold (1.15 log units) above the measured number, and the stated range ends above it.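

In this assay, within the data shown here, methyl in place of phenyl on the amide-type ring nitrogen gives an at least 7.1-fold lower number from compound 1 to compound 3 (0.85 log units; beyond the scatter), the first readable step and one that shows this position is not indifferent to its substituent. For compound 1 the value is a limit, so the step has a floor but no known full size: the limit of > 0.15 umol/kg in this assay, at which 1 of the 3 values shown sits.

The phenyl group is therefore not needed at this nitrogen for an effect at small amounts, since compound 3, with only methyl there, gives 0.021 umol/kg in this assay.

As far as these compounds go, with one change at this position, it remains open whether the step follows from losing the aromatic ring or from the smaller substituent, and the amide hydrogen, ethyl, cyclohexyl or benzyl at the same nitrogen would help separate these readings. From the compounds shown here alone, it is also open whether the same change would hold on other versions of the shared core, and a whole-organism number alone does not say which processes within the animal account for the step.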